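The source may report more compounds than this note shows. Statements on the series, on what has been measured and on what is new or still open speak of the compounds shown alone.

The compounds measured so far:

Compound 1, `O=C(Nc1ccccc1F)c1cccc2[nH]c(-c3ccc([N+](=O)[O-])o3)nc12`: in an ADME assay on Vero cells (Chlorocebus sabaeus) for cytotoxicity (a lower number here means that less compound is tolerated, a higher number that more compound is tolerated), compound 1 gives 75.9 uM.
Compound 2, `COc1ccc(-c2nc3c(C(=O)Nc4ccccc4F)cccc3[nH]2)cc1OC`: in this assay compound 2 gives 24.5 uM.

Compound 2 stands at the lowest of the two numbers; the nearest is compound 1, whose number is higher by a margin that lies beyond the usual scatter of the measurement. For the measured compounds named here, no pair of measured compounds differs in a single place, so no measured step exists to lean on.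

Compound 3, `COc1ccc(-c2nc3c(C(=O)NCCCO)cccc3[nH]2)cc1OC`, has not yet been measured in this assay. It differs from compound 2 in one place: 3-hydroxypropyl in place of 2-fluorophenyl on an amide-type nitrogen. Going by the values given here, with no comparable step among the measured compounds, the expectation rests on the structural change alone. For compound 3 a modest step toward a higher number is expected, a 2.0-fold higher number from compound 2 to compound 3 (0.31 log units; beyond the scatter), though a step within the scatter cannot be ruled out. Compound 3 is therefore estimated at 50 uM, within a range from 20 uM to 150 uM.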

Compound 3, half-maximal toxic concentration: 46 uM
The estimate for compound 3 lay 1.1-fold (0.04 log units) above the measured number, within the range that was stated.
By their numbers in this assay, from the lowest: compounds 2, 3 and 1 (each within the scatter of the next, the first and the last beyond it).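

For the compounds shown here, the step of a 1.9-fold higher number from compound 2 to compound 3 (0.27 log units; within the scatter) in this assay is the first measured change at this amide-type nitrogen. It shows that 2-fluorophenyl, with its six-membered aromatic ring, can be replaced by the open 3-hydroxypropyl chain, with fewer heavy atoms and a hydrogen-bond donor and acceptor added, without a change in this read-out that stands clear of the scatter. No measurement shown here offers an explanation for this result.

From the compounds shown here alone, whether an amine, a carboxylic acid or a longer chain on this nitrogen would leave the number in the same range remains open. Going by these compounds, it is also open whether 3-hydroxypropyl in place of 2-fluorophenyl would give a similar step on the core of compound 1.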